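A few compounds are considered here, and "the series" means these few. Any claim that something is new, unique, unknown or untested is made for them only; others in the source may bear on it.

Measured in a functional assay on HCT-116 cells (Homo sapiens) for antiproliferative activity, read by MTT assay, with a stated time of 48 h; on this read-out lower numbers stand for stronger inhibition and higher numbers for weaker inhibition:
- Compound 1 `COc1ccc(N(C)c2ccnc(Cl)n2)cc1O`: 422 nM
- Compound 2 `COc1ccc(N(C)c2ccnc(Cl)n2)cc1OCCBr`: 5670 nM
- Compound 3 `COc1ccc(N(C)c2ccnc(Cl)n2)cc1OCCCCBr`: 1140 nM

Compound 3 stands second highest of these three numbers, with compound 1 below it and compound 2 above it. Relative to the free hydroxyl of compound 1, the two bromoalkyl ethers both gave higher numbers: a 13-fold higher number from compound 1 to compound 2 (1.13 log units; beyond the scatter) and a 2.7-fold higher number from compound 1 to compound 3 (0.43 log units; beyond the scatter). Compound 4 `COc1ccc(N(C)c2ccnc(Cl)n2)cc1OCCCCCBr` has not yet been measured. Its difference from compound 3 is bromomethyl in place of bromo on a saturated chain carbon, four bonds along the chain from an oxygen on an aromatic ring.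

Going by the values given here, the closest precedent is the same kind of change further down the chain, a 5.0-fold lower number from compound 2 to compound 3 (0.70 log units; beyond the scatter). That single step went toward a lower number, but one step does not establish a trend. Compound 3 also lies nearer to compound 1 than to compound 2, leaving less room for a further fall. A smaller step in this assay is therefore expected, leaning lower and quite possibly not beyond the scatter. The expected change is a 1.3-fold lower number from compound 3 to compound 4 (0.10 log units; within the scatter). The estimated value for compound 4 is 900 nM, with an expected range of 350 nM to 2500 nM.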

Compound 4, half-maximal inhibitory concentration: > 10000 nM
Compound 4: no number, only a limit; the forecaster's own chance of this, stated with the estimate: 2%; at least 11-fold (1.04 log units) between middle value and limit.
By their numbers in this assay, from the lowest: compound 1; then compound 3; then compound 2. At a limit, above all of these: compound 4.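

Compound 4 gave no number in this assay, only a limit: the limit of > 10000 nM in this assay, at which 1 of the 4 values shown sits.

The fall in the number seen from 2-bromoethyl to 4-bromobutyl did not carry on to 5-bromopentyl, and the direction reversed, an at least 8.7-fold higher number from compound 3 to compound 4 (0.94 log units; beyond the scatter), so lengthening this chain does not move the number one way throughout these compounds. The free hydroxyl keeps the lowest number, and the gap to it is now the widest in the set, an at least 23-fold higher number from compound 1 to compound 4 (1.37 log units; beyond the scatter), whereas an at least 1.7-fold higher number from compound 2 to compound 4 (0.24 log units; that floor lies within the scatter), and that floor alone does not set the two bromoalkyl ethers apart.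

From the compounds shown here alone, how far above the limit compound 4 truly lies remains open. Also open, going by these compounds, are where a 3-bromopropyl chain would fall and whether an amine in place of the bromo would give the same turn with chain length.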